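The compounds below may be only part of what the source reports. "The series", "measured", "known", "first", "only" and "open" are said of these compounds alone.

Three compounds have so far been measured in a functional assay on the whole organism (Tail, strain ICR) with Mus musculus as the target, in the tail flick test, with a stated time of 90 min, at a dose of 25 umol/kg by the oral route; a higher number here means a stronger effect of the compound at the dose given, a lower number a weaker effect:

compound 1 `CC[C@H](C)[C@H](NC(=O)CN(c1ncnc2c1ncn2C1CCCCO1)C1CC1)C(=O)OCc1ccccc1` gives 22.6%
compound 2 `O=C(CN(c1ncnc2c1ncn2C1CCCCO1)C1CC1)N[C@@H](CO)C(=O)OCc1ccccc1` gives 32.2%
compound 3 `NCCCC[C@H](NC(=O)CN(c1nc(Cl)nc2[nH]cnc12)C1CC1)C(=O)O` gives 28.8%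

Compound 2 holds the highest of the three numbers, yet compound 3 and compound 1 both lie within the scatter of it, so no order among the three can be read from these values. Compound 4 `CC(C)(C)OC(=O)NCCCC[C@H](NC(=O)CN(c1ncnc2c1ncn2C1CCCCO1)C1CC1)C(=O)OCc1ccccc1` differs from compound 2 in one place: 3-((tert-butoxycarbonyl)amino)propyl in place of hydroxy on a saturated chain carbon, two bonds along the chain from an amide-type nitrogen and a carbonyl carbon. For the measured compounds named here, only one measured step touches the same place, namely a number 9.6 percentage points higher from compound 1 to compound 2 (within the scatter), and it stayed within the scatter; compound 3 carries a different core, and no step to it is given. The expectation is therefore a step of a number 4.2 percentage points lower from compound 2 to compound 4 (within the scatter), not beyond the scatter. Compound 4 is estimated at 28%, in a range from 12% to 44%.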

Compound 4, a percentage reported as activity, at one dose (the size of the read-out at that dose, not a potency): 32.9%
For compound 4 the middle estimate is 4.9 percentage points below the measured one; measured number inside the range.
By their numbers in this assay, from the lowest: compounds 1, 3, 2 and 4 (each within the scatter of the next, the first and the last beyond it).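

With 3-((tert-butoxycarbonyl)amino)propyl, 11 heavy atoms, in place of hydroxy, the result in this assay is a number 0.7 percentage points higher from compound 2 to compound 4 (within the scatter), so this position accepts a much larger chain without a step beyond the scatter. Set against sec-butyl, 4-((tert-butoxycarbonyl)amino)butyl gives a number 10.3 percentage points higher from compound 1 to compound 4 (beyond the scatter), the first step at this position beyond the scatter. Nothing available explains either result. On these data alone, on the shared core, it remains open how a free amine at the end of this chain, or a longer chain, would compare.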